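Fluoro in place of methoxy on a fused bicyclic aminothiazole

The compounds below may be only part of what the source reports. "The series", "measured", "known", "first", "only" and "open" are said of these compounds alone.

Compound 2 `COc1ccc2nc(Nc3ccnc(Nc4ccc(S(C)(=O)=O)cc4)n3)sc2c1` stands second highest of three numbers in a functional assay on HeLa cells (Homo sapiens) for antiproliferative activity, read by MTT assay, with a stated time of 48 h (on this read-out higher numbers stand for weaker inhibition and lower numbers for stronger inhibition), where compound 2 gives 4130 nM. Compound 3 `COc1ccc2nc(Nc3nc(Nc4ccc(S(C)(=O)=O)cc4)ncc3F)sc2c1` gives 25400 nM, and compound 1 `NS(=O)(=O)c1ccc(Nc2nccc(Nc3nc4ccc(F)cc4s3)n2)cc1` gives 450 nM. Compound 4 `CS(=O)(=O)c1ccc(Nc2nccc(Nc3nc4ccc(F)cc4s3)n2)cc1` differs from compound 2 by fluoro in place of methoxy on an aromatic carbon. Going by the values given here, the only measured step, a 6.2-fold higher number from compound 2 to compound 3 (0.79 log units; beyond the scatter), concerns a different position and does not bear directly on this change. Among the compounds with values here, no measured pair shows methoxy against fluoro at this place. Compound 1, which carries the same fluoro, gives 450 nM, so compound 4 is expected to reach a lower number than compound 2, a step of a 3.4-fold lower number from compound 2 to compound 4 (0.54 log units; beyond the scatter). Compound 4 is estimated at 1200 nM, within 350 nM to 4000 nM.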

Compound 4, half-maximal inhibitory concentration: 560 nM
Beside the measured number, compound 4's estimate is 2.1-fold (0.33 log units) above it; low and high end bracket the measured number.
By their numbers in this assay, from the lowest: compounds 1 and 4 (each within the scatter of the next); then compound 2; then compound 3.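

In this assay, going by these compounds alone, fluoro in place of methoxy on the aromatic carbon gives a 7.4-fold lower number from compound 2 to compound 4 (0.87 log units; beyond the scatter) and so supplies the first direct pair for this position, where the earlier compounds offered none. With the fluoro kept, methyl in place of amino on the sulfonyl sulfur gives a 1.2-fold higher number from compound 1 to compound 4 (0.09 log units; within the scatter) and so makes no measurable difference, which shows that the low number of compound 1 recurs with either group on the sulfur.

On these data alone, what chloro, an amine or a longer alkoxy chain would give at this place stays open, as does whether the step from methoxy to fluoro holds with amino on the sulfonyl sulfur. Nothing among the data gives a reason for either step.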